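The compounds below may be only part of what the source reports. "The series", "measured", "known", "first", "only" and "open" are said of these compounds alone.

Three sulfonamides were tested in an ADME assay on HCT-116 cells (Homo sapiens) for cytotoxicity, read by CellTiter-Glo, with a stated time of 72 h; a higher number here means a weaker inhibitor, a lower number a stronger inhibitor. Compound 1 `Cc1cc(C)c(S(=O)(=O)NCCN2CCC(C)CC2)c(C)c1` gives > 5000 nM, which is a limit of the assay rather than a number. Compound 2 `Cc1ccc(S(=O)(=O)N2CCC(N3CCC(C)CC3)CC2)cc1C` gives > 5000 nM, again a limit and not a number. Compound 3 `CC1CCN(C2CCN(S(=O)(=O)c3sc(Cl)nc3C3CC3)CC2)CC1` gives > 10000 nM, likewise a limit. Compound 2 therefore stands at the limit of > 5000 nM in this assay, at which 2 of the 3 values shown sit. Compound 3 sits at the limit of > 10000 nM in this assay, at which 1 of the 3 values shown sits. Going by the values given here, no two measured compounds differ in only one place, so no step between measured compounds can be read off, and none of the three shows a number that could anchor a trend.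

Compound 4 `CC1CCN(C2CCN(S(=O)(=O)c3ccc(Cl)c(Cl)c3)CC2)CC1` has not yet been measured in this assay. It differs from compound 2 by 3,4-dichlorophenyl in place of 3,4-dimethylphenyl on a sulfonyl sulfur. Among the compounds with values here, every value so far is a limit; the data give no direction for this change. The expected step is a step that the limit leaves unreadable from compound 2 to compound 4, that is, nothing beyond the usual scatter. Compound 4 is accordingly expected near 10000 nM, with a likely range from 3000 nM to 40000 nM, and most probably the assay will again report only a limit.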

Compound 4, half-maximal inhibitory concentration: > 5000 nM
Compound 4: a limit, no number; the forecaster's own chance of this, stated with the estimate: 80%; the middle value lies beyond the limit too.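

Compound 2 and compound 4 both give only a limit, so the step from 3,4-dimethylphenyl to 3,4-dichlorophenyl on the sulfonyl sulfur cannot be read. The compounds shown leave open what this change does to a numerical value in this assay.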